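Opening a ring amide into an ester-bearing chain

A few compounds are considered here, and "the series" means these few. Any claim that something is new, unique, unknown or untested is made for them only; others in the source may bear on it.

Of the compounds shown here, two of a shared core have been tested in a functional assay on the whole organism with Mus musculus as the target; on this read-out lower numbers stand for an effect already at smaller amounts and higher numbers for an effect only at larger amounts of compound. Compound 1 `CN(C)C(=O)Cn1c(-c2ccc(C(F)(F)F)cc2)nc2cccnc21` gives 3.2 mg/kg. Compound 2 `O=C(Cn1c(-c2ccc(Cl)cc2)nc2cccnc21)N1CCCC1` gives 17.9 mg/kg, the highest of the two numbers, so compound 2 needs the larger amount. Compound 3 `CCOC(=O)CCCNC(=O)Cn1c(-c2ccc(Cl)cc2)nc2cccnc21` has not yet been measured; it differs from compound 2 by one change ((3-(ethoxycarbonyl)propyl)amino in place of pyrrolidin-1-yl on a carbonyl carbon). For the measured compounds named here, no measured pair shows this kind of exchange, so its effect is unknown. For compound 3 the expectation is a step of a 1.1-fold higher number from compound 2 to compound 3 (0.05 log units; within the scatter) that stays within the usual scatter of this assay, with a value of about 20 mg/kg and a range from 7 mg/kg to 60 mg/kg.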

Compound 3, dose for half-maximal effect: 100 mg/kg
Compound 3: middle estimate off by 5.0-fold (0.70 log units), on the low side; measured number above the stated range.
By their numbers in this assay, from the lowest: compound 1; then compound 2; then compound 3.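

In this assay the exchange of pyrrolidin-1-yl for the open (3-(ethoxycarbonyl)propyl)amino chain on the carbonyl carbon gives a 5.6-fold higher number from compound 2 to compound 3 (0.75 log units; beyond the scatter) and so shows that the read-out responds to the group at this place. A ring amide and this ester-bearing chain are therefore not interchangeable here. What lies behind the step is not shown by any measurement at hand.

This one change replaces a ring with a chain and also brings in an ester, and the compounds shown cannot separate these two features. A plain butylamino chain or the matching carboxylic acid would address that question.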